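This account rests on a few compounds, and the source may have more. Where it says the series, first, only, none or still open, it means among the compounds named here.

Measured so far:
- compound 1, `COc1cc(C)cc(-c2c(-c3ccnc(-c4ccc(C(C)=O)cc4)c3)cnn2CC#N)c1`: 97%
- compound 2, `Cc1cc(O)cc(-c2nn(CC#N)cc2-c2ccnc(-c3ccc(Oc4ccccc4)cc3)c2)c1`: 88%

Both compounds were tested in a functional assay on SF-268 cells (Homo sapiens) for cytotoxicity, read by sulforhodamine B assay, with a stated time of 48 h, tested at 0.001 uM; on this read-out higher numbers stand for a weaker effect at the one concentration tested and lower numbers for a stronger effect. In this assay compound 1 gives 97% and compound 2 gives 88%. The two numbers lie within the usual scatter of each other, so neither compound can be called stronger or weaker than the other on these data; both readings sit near the top of the scale, which at the one concentration tested means little effect for either.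

Compound 3, `Cc1cc(O)cc(-c2nn(CC#N)cc2-c2ccnc(-c3ccc(N(C)C)cc3)c2)c1`, has not yet been measured. It differs from compound 2 in one place: dimethylamino in place of phenoxy on an aromatic carbon. Among the measured compounds shown here, no step between measured compounds involves this kind of change, so there is no measured guide for it. Since both known values crowd near the top of the scale, the step from compound 2 to compound 3 is expected to be a number 4 percentage points higher from compound 2 to compound 3 (within the scatter), which is no change beyond the scatter. Compound 3 is therefore estimated at 92%, with a range from 78% to 100%.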

Compound 3, a percentage reported as activity, at one concentration (the size of the read-out at that concentration, not a potency): 97%
The estimate for compound 3 lay 5 percentage points below the measured number; low and high end bracket the measured number.
By their numbers in this assay, from the lowest: compounds 2, 1 and 3 (each within the scatter of the next).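

Among the compounds shown here, at this position, an aromatic carbon para to a large group, putting dimethylamino in place of phenoxy gives a number 9 percentage points higher from compound 2 to compound 3 (within the scatter) in this assay, the first step here between compounds that differ in one place. The swap takes away a whole six-membered aromatic ring and leaves a much smaller group with no ring, yet the two compounds cannot be told apart, so at this one concentration the reading does not depend on that ring being present. Nothing measured here offers an explanation for this result.

The compounds shown leave open whether a carboxylic acid or a longer chain such as butoxy at the same carbon would read differently in this assay. They also leave open whether phenoxy and dimethylamino would separate at any other concentration.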